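Hydrazone Variations on a Shared Nucleoside Core

The source may hold more compounds than are shown below. What is called first, only, known or untested is meant among the compounds shown, and "the series" means these compounds.

Measured so far:
- Compound 1 `CC(=O)Nc1ccc(/C=N/Nc2nc(N)c3ncn([C@@H]4O[C@H](CO)[C@@H](O)[C@H]4O)c3n2)cc1` gives 0% in an assay on CHO-K1 cells for displacement of a labelled ligand from adenosine receptor A1 (Homo sapiens), read by scintillation counting, with a stated time of 60 min, tested at 1 uM; on this read-out lower numbers stand for less inhibition and higher numbers for more inhibition at the one concentration tested (going by the name of the read-out).
- Compound 2 `CSCC/C=N/Nc1nc(N)c2ncn([C@@H]3O[C@H](CO)[C@@H](O)[C@H]3O)c2n1` gives 0% in this assay.

Compound 2 stands level with compound 1, with no change at the digits printed from compound 1 to compound 2 (within the scatter). Compound 3 `CCCOc1ccc(/C=N/Nc2nc(N)c3ncn([C@@H]4O[C@H](CO)[C@@H](O)[C@H]4O)c3n2)cc1` has not yet been tested. It differs from compound 2 by 4-propoxyphenyl in place of 2-(methylsulfanyl)ethyl on a carbon with a double bond to nitrogen. Among the compounds with values here, the only comparable step is the one from compound 1 to compound 2, which also swapped a ring-bearing group against a chain at this carbon and produced nothing beyond the scatter. Compound 3 is therefore expected to give about 0%, between -8% and 12%, an expected step of no change at the digits printed from compound 2 to compound 3 (within the scatter).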

Compound 3, a percentage reported as inhibition, at one concentration (the size of the read-out at that concentration, not a potency): 7%
Compound 3: middle estimate off by 7 percentage points, on the low side; the measured number falls inside the stated range.
By their numbers in this assay, from the lowest: compounds 1, 2 and 3 (each within the scatter of the next).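

In this assay, 4-propoxyphenyl at this carbon gives a number 7 percentage points higher from compound 2 to compound 3 (within the scatter) and propoxy in place of acetamido on an aromatic carbon gives a number 7 percentage points higher from compound 1 to compound 3 (within the scatter). This carbon has now carried a chain and two different aromatic groups, and no swap among them has moved the number beyond the scatter. Nothing available explains this outcome. Still open, as far as these compounds go, is whether a carboxylic acid or an amine on the aromatic ring, or a longer chain at this carbon, would produce a step beyond the scatter.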